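Swapping Methyl for Trifluoromethyl on a Sulfonyl Sulfur

The source may hold more compounds than are shown below. What is called first, only, known or untested is meant among the compounds shown, and "the series" means these compounds.

Of the compounds shown here, two have so far been measured in a physicochemical assay for lipophilicity; a lower number here means a more polar compound, a higher number a more lipophilic compound. Compound 1 `CCN(CC)CCCn1cc[n+](C)c1/C=N/O` gives -2.78. Compound 2 `CN(CCCn1cc[n+](C)c1/C=N/O)S(C)(=O)=O` gives -2.63. On these two numbers compound 2 stands at the top of the pair, yet the step of a number 0.15 log units higher from compound 1 to compound 2 (within the scatter) lies within the usual scatter of repeated measurements, so the two compounds cannot really be told apart. That step replaced a diethylamino group with a methyl(methylsulfonyl)amino group on a saturated chain carbon, three bonds along the chain from an aromatic nitrogen.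

The next compound, compound 3 `CN(CCCn1cc[n+](C)c1/C=N/O)S(=O)(=O)C(F)(F)F`, is compound 2 with one change: trifluoromethyl in place of methyl on a sulfonyl sulfur. Among the compounds with values here, no measured step touches the sulfonyl sulfur, so nothing measured speaks directly to this change; the single step available altered a different part of the molecule and stayed within the scatter. Within the data shown here, with no comparable step to lean on, the expectation in this assay is a small rise, estimated at a number 0.53 log units higher from compound 2 to compound 3 (beyond the scatter). Compound 3 is therefore expected to give about -2.1, with a range from -2.6 to -1.6.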

Compound 3, distribution coefficient: -1.37
Estimate against measurement, compound 3: 0.73 log units below; measured number above the stated range.
By their numbers in this assay, from the lowest: compounds 1 and 2 (each within the scatter of the next); then compound 3.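

The sulfonyl sulfur turns out to be a position where one small substitution clearly shifts the read-out in this assay: the swap of methyl for trifluoromethyl gives a number 1.26 log units higher from compound 2 to compound 3 (beyond the scatter), even though 1 heavy atom leaves, 4 heavy atoms enter, and the count of hydrogen-bond donors, hydrogen-bond acceptors and net charge stays the same. Within the data shown here, the earlier change on the saturated chain, a number 0.15 log units higher from compound 1 to compound 2 (within the scatter), could not separate its two compounds, so this is the first single change that produces a difference larger than repeat measurements would. Nothing available accounts for the size of this rise.

With only methyl and trifluoromethyl shown on the sulfonyl sulfur, it remains open how the number would respond to a partly fluorinated group such as difluoromethyl, to a longer chain such as ethyl, or to a phenyl ring at that place. Also open, going by these compounds, is whether the same swap would give a step of similar size if an ethyl group replaced the methyl on the sulfonamide nitrogen.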